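The source may report more compounds than this note shows. Statements on the series, on what has been measured and on what is new or still open speak of the compounds shown alone.

Working notes on the series in an in vitro functional assay on RBL cells for antagonist activity at C-C chemokine receptor type 8 (Homo sapiens), read by FLIPR and calcium flux; a higher number here means a weaker inhibitor, a lower number a stronger inhibitor. Two compounds carry a number. Compound 2 `O=C1OC(c2ccnc3ccccc23)CN1C1CCN(Cc2cc3ccccc3[nH]2)CC1` gives 1000 nM in this assay. Compound 3 `COc1ccc2nccc(C3CN(C4CCN(Cc5cc6ccccc6n5C)CC4)C(=O)O3)c2c1` gives 3160 nM in this assay, the higher of the two numbers, and its gap to compound 2 lies beyond the scatter. Compound 1 `COc1ccc2nccc(C3CN(C4CCCCN(Cc5cc6ccccc6[nH]5)C4)C(=O)O3)c2c1` gives < 50200 nM in this assay, which is a limit and not a number. Compound 1 is thus reported in this assay only as a limit: the limit of < 50200 nM in this assay, at which 1 of the 3 values shown sits.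

Within the data shown here, no two measured compounds differ in a single place, so no measured step is available to calibrate the change considered next. Compound 4 `COc1ccc(CN2CCC(N3CC(c4ccnc5ccc(OC)cc45)OC3=O)CC2)cc1` is not yet measured. Its difference from compound 3 is 4-methoxyphenyl in place of 1-methyl-1H-indol-2-yl on a saturated chain carbon bound to an amine nitrogen in a ring. The change keeps one hydrogen-bond acceptor and no donor, and replaces the two-ring 1-methyl-1H-indol-2-yl with the one-ring 4-methoxyphenyl on the saturated chain carbon bound to the ring amine nitrogen.

Among the measured compounds shown here, with no measured step of this kind, the expectation rests on the shared core and on compound 3 as the closest point. A step of a 1.6-fold higher number from compound 3 to compound 4 (0.20 log units; within the scatter) is expected, toward a higher number, of a size that may or may not exceed the scatter. Compound 4 is therefore estimated at 5000 nM in this assay, with a range from 1500 nM to 20000 nM.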

Compound 4, half-maximal inhibitory concentration: 1260 nM
Compound 4: the middle estimate sits 4.0-fold (0.60 log units) above what was measured, and the stated range ends above it.
By their numbers in this assay, from the lowest: compounds 2 and 4 (each within the scatter of the next); then compound 3.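

In this assay, among these compounds, the change of 4-methoxyphenyl in place of 1-methyl-1H-indol-2-yl on a saturated chain carbon bound to an amine nitrogen in a ring gives the first measured step: a 2.5-fold lower number from compound 3 to compound 4 (0.40 log units; beyond the scatter). The step is modest but beyond the scatter, and it shows that at this place the two-ring 1-methyl-1H-indol-2-yl is not needed for activity and that the one-ring 4-methoxyphenyl gives the lower number on this core. Among the compounds shown here, nothing measured so far bears on what lies behind this step.

Going by these compounds, the series still rests on this single step, so it remains open whether the gain belongs to the 4-methoxybenzyl group as a whole or to its methoxy group alone, a question that plain benzyl, 4-chlorobenzyl or 4-hydroxybenzyl at the same place would address. Also open, on these data alone, is whether a six-membered aromatic ring containing nitrogen, as in pyridin-3-ylmethyl, or a 4-carboxybenzyl group would hold the number of compound 4 at 1260 nM.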